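The source may report more compounds than this note shows. Statements on the series, on what has been measured and on what is new or still open speak of the compounds shown alone.

Of the compounds shown here, three in a single series have been measured in a functional assay for antagonist activity at Oxoeicosanoid receptor 1 (Homo sapiens), read by fluorescence and calcium flux, with stated times of 2 min and 1 min; a higher number here means a weaker inhibitor, a lower number a stronger inhibitor. Compound 1, with the structure `CC(CC(=O)O)CC(=O)c1c(CCCCCC(F)(F)F)n(C)c2ccc(Cl)cc12`, gives 38 nM in this assay. Compound 2, whose structure is `CC(CC(=O)O)CC(=O)n1c(CCCc2ccccc2)cc2ccc(Cl)cc21`, gives 210 nM in this assay. Compound 3, built as `C[C@@H](CC(=O)O)CC(=O)c1c([C@H](O)CCCCCc2ccccc2)n(C)c2ccc(Cl)cc12`, gives 750 nM in this assay. Among these three numbers compound 2 stands second highest: compound 3 lies nearest to it, with a higher number beyond the usual scatter, and compound 1 lies furthest away, with a lower number that is also beyond the scatter.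

The next compound, compound 4, has the structure `CC(CC(=O)O)CC(=O)n1c(CCCCc2ccccc2)cc2ccc(Cl)cc21`. It differs from compound 2 in one place: benzyl in place of phenyl on a saturated chain carbon, three bonds along the chain from an aromatic carbon. Within the data shown here, no pair of measured compounds differs by exactly this change, so the size of the step can only be guessed from the three values in hand.

The account expects that lengthening the chain in this way will leave the number close to where compound 2 stands, with a step of a 1.4-fold lower number from compound 2 to compound 4 (0.15 log units; within the scatter) that is unlikely to go beyond the scatter and, if anything, points slightly downward. Compound 4 is therefore estimated at 150 nM in this assay, with a range from 50 nM to 450 nM.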

Compound 4, half-maximal inhibitory concentration: 18 nM
Compound 4: middle estimate off by 8.3-fold (0.92 log units), on the high side; measured number below the stated range.
By their numbers in this assay, from the lowest: compound 4; then compound 1; then compound 2; then compound 3.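

In this assay, this position on the saturated chain turns out to be highly sensitive: benzyl in place of phenyl, three bonds along the chain from an aromatic carbon, gives a 12-fold lower number from compound 2 to compound 4 (1.07 log units; beyond the scatter) and is a large step well beyond the scatter. Read one bond further out, the same difference is phenethyl to 3-phenylpropyl, and both groups end in the same six-membered aromatic ring of carbon only, with no hydrogen-bond donors or acceptors and no net charge on either side, so chain length alone separates compound 2 from compound 4 and is enough to move the number strongly, something the earlier compounds could not show since none of them differed from another in one place. Nothing available explains why this small extension has so large an effect.

The compounds shown leave open whether a longer chain at this place would take the number further down or send it back up, and so whether compound 4 lies near an optimum in chain length. They also leave open whether an ether oxygen or an amine within the chain would keep this gain, and whether the same extension would have a similar effect on the core of compound 1.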